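Compound 1 and a pyrimidin-5-yl replacement

The source may report more compounds than this note shows. Statements on the series, on what has been measured and on what is new or still open speak of the compounds shown alone.

In a physicochemical assay for solubility, read by nephelometry, measured as kinetic solubility, at pH 6.5 (on this read-out higher numbers stand for higher solubility and lower numbers for lower solubility), compound 1 (`OC(c1ccc(Cl)cc1)(c1cccnc1)c1ccccc1Cl`) gives 3.1 ug/mL as the lower of the two numbers at hand, and compound 2 (`N#Cc1ccc(C(O)(c2ccc(C(F)(F)F)cc2)c2cccnc2)c(F)c1`) gives 6.3 ug/mL with a gap beyond the usual scatter. Compound 3 (`OC(c1ccc(Cl)cc1)(c1cccnc1)c1cncnc1`) carries pyrimidin-5-yl in place of 2-chlorophenyl on a saturated chain carbon bound to two aromatic carbons and an oxygen on a saturated carbon. Among the compounds with values here, no measured pair shows such a change, so a rise in this assay beyond the scatter is only an expectation drawn from the structural change. The expected size is a 13-fold higher number from compound 1 to compound 3 (1.11 log units; beyond the scatter) as an estimate. Compound 3 is estimated at 40 ug/mL within a range of 12 ug/mL to 120 ug/mL here.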

Compound 3, solubility: > 100 ug/mL
Compound 3: only a limit was reported; the forecaster's own chance of this, stated with the estimate: 10%; middle value at least 2.5-fold (0.39 log units) from the limit.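

Within the data shown here, the first one-place step in this set falls on the saturated chain carbon bound to two aromatic carbons and an oxygen on a saturated carbon, where pyrimidin-5-yl in place of 2-chlorophenyl gives an at least 32-fold higher number from compound 1 to compound 3 (1.50 log units; beyond the scatter) in this assay as the read-out. The reading for compound 3, > 100 ug/mL in this assay, is a limit and not a number. The step therefore marks only a floor, because it rests on that limit: the limit of > 100 ug/mL in this assay, at which 1 of the 3 values shown sits.

The compounds shown leave open how this step divides between losing the chlorine and gaining the ring nitrogens. They also leave open whether a plain phenyl, a pyridin-3-yl or a ring bearing an amine at this place would give a step of similar size.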